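From 4-methylphenyl to 2-nitrophenyl: does growth inhibition appear?

The source may report more compounds than this note shows. Statements on the series, on what has been measured and on what is new or still open speak of the compounds shown alone.

- Compound 1 `CC1=CC[C@@H]([C@@](C)(O)CCCC(C)(C)NC=S)CC1` gives > 100000 nM as a limit
- Compound 2 `CC1=CC[C@@H]([C@@](C)(O)CCCC(C)(C)NC(=S)N/N=C\c2ccc(C)cc2)CC1` gives > 100000 nM as a limit

In a functional assay on NCI-H460 cells (Homo sapiens) for cytotoxicity, read by sulforhodamine B assay (on this read-out higher numbers stand for weaker inhibition of growth and lower numbers for stronger inhibition of growth), compound 2 gives > 100000 nM as a limit of the assay and not a number. The record so far is the limit of > 100000 nM in this assay, at which 2 of the 2 values shown sit, and nothing more, so no true value exists yet to compare against.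

Compound 3 `CC1=CC[C@@H]([C@@](C)(O)CCCC(C)(C)NC(=S)N/N=C\c2ccccc2[N+](=O)[O-])CC1` carries 2-nitrophenyl in place of 4-methylphenyl on a carbon with a double bond to nitrogen and otherwise matches compound 2. Among the measured compounds shown here, no measured step shows what this swap does, so no change beyond the scatter is expected in this assay. The expected size of the change is a number no higher from compound 2 to compound 3 (the limit leaves the size open) as a rough estimate. For compound 3 the expected value is 100000 nM with an estimated range from 40000 nM to 200000 nM and it may well turn out to be only a limit.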

Compound 3, concentration for total growth inhibition: > 100000 nM
Compound 3 gave a limit, no number; the forecaster's own chance of this, stated with the estimate: 70%; the middle value lies on the limit itself.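

Among the compounds shown here, compound 2 and compound 3 each give a limit and not a number, so the swap from 4-methylphenyl to 2-nitrophenyl yields no step that can be read: the limit of > 100000 nM in this assay, at which 3 of the 3 values shown sit. Going by these compounds, whether this swap changes growth inhibition at all, and by how much, stays open.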